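Aryloxy enone series: amine replacement at the chain terminus

A few compounds are considered here, and "the series" means these few. Any claim that something is new, unique, unknown or untested is made for them only; others in the source may bear on it.

Measured so far:
- compound 1 `CC(=O)/C(=C\c1ccccc1)Oc1ccccc1OCCCNC(C)(C)C`: 1.5 mg/kg
- compound 2 `CC(=O)/C(=C\c1ccccc1)Oc1ccc(OCC(O)NC(C)(C)C)cc1`: 3.5 mg/kg

In a functional assay on the whole organism (heart) with Rattus norvegicus as the target (on this read-out higher numbers stand for an effect only at larger amounts of compound and lower numbers for an effect already at smaller amounts), compound 1 gives 1.5 mg/kg, the lowest number among the two measured compounds. Compound 2 gives a higher number in this assay, 3.5 mg/kg, and that gap lies beyond the scatter; as compounds 1 and 2 differ in more than one place, their two values show this and nothing more.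

Compound 3 `CC(=O)/C(=C\c1ccccc1)Oc1ccccc1OCCCN1CCN(C)CC1` keeps the core of compound 1 and changes only the amine at the chain end: 4-methylpiperazin-1-yl in place of (tert-butyl)amino on a saturated chain carbon, three bonds along the chain from an oxygen on an aromatic ring. The (tert-butyl)amino group leaves and 4-methylpiperazin-1-yl enters on a saturated chain carbon, three bonds along the chain from an oxygen on an aromatic ring.

Among the measured compounds shown here, no measured pair isolates this change, so there is no step to lean on. The expectation is a modest move toward a higher number, possibly no larger than the scatter, with the step from a 1.7-fold higher number from compound 1 to compound 3 (0.22 log units; within the scatter) estimated as small. For compound 3 the estimate in this assay is 2.5 mg/kg, with a range from 0.8 mg/kg to 8 mg/kg.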

Compound 3, dose for half-maximal effect: 2.5 mg/kg
For compound 3 middle estimate and measured number coincide at the digits printed, within the range that was stated.
By their numbers in this assay, from the lowest: compounds 1, 3 and 2 (each within the scatter of the next, the first and the last beyond it).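

Among the compounds shown here, this is the first single-place comparison. In this assay, 4-methylpiperazin-1-yl in place of (tert-butyl)amino on a saturated chain carbon, three bonds along the chain from an oxygen on an aromatic ring, gives a 1.7-fold higher number from compound 1 to compound 3 (0.22 log units; within the scatter), so this read-out does not tell the two amines apart. On the core of compound 1, then, the chain end tolerates a swap from an open group with 1 hydrogen-bond donor to a six-membered non-aromatic ring with 0 hydrogen-bond donors and 2 hydrogen-bond acceptors, without a difference beyond the scatter. Nothing at hand bears on why the result comes out this way.

Still open, as far as these compounds go, is whether this tolerance reaches other amines at the chain end, such as morpholin-4-yl, piperidin-1-yl or dimethylamino, or a non-amine terminus such as a carboxylic acid. Also open, from the compounds shown here alone, is whether 4-methylpiperazin-1-yl behaves the same way on a longer chain, or on the hydroxyl-bearing chain of compound 2, whose differences from compound 1 lie in more than one place.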